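Compound 3 to compound 4: butoxy replaced by methyl

A few compounds are considered here, and "the series" means these few. Any claim that something is new, unique, unknown or untested is made for them only; others in the source may bear on it.

In a functional assay on MDA-MB-231 cells (Homo sapiens) for antiproliferative activity, read by MTT assay, with a stated time of 24 h (a lower number here means a stronger inhibitor, a higher number a weaker inhibitor), compound 3 `CCCCOc1ccc(C(=O)NNC(=O)c2cccc(NS(=O)(=O)c3cnc(O)nc3O)c2)cc1` gives 17000 nM. This is the higher of the two actual numbers, with compound 2 `O=C(NNc1ccccc1Cl)c1cccc(NS(=O)(=O)c2cnc(O)nc2O)c1` at 2090 nM. Compound 1 `Cc1cccc(NNC(=O)c2cccc(NS(=O)(=O)c3cnc(O)nc3O)c2)c1` gives > 20000 nM, which is a limit of the assay and not a number.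

Compound 4 `Cc1ccc(C(=O)NNC(=O)c2cccc(NS(=O)(=O)c3cnc(O)nc3O)c2)cc1` has methyl in place of butoxy on an aromatic carbon, para to a large group (methyl in place of butoxy on an aromatic carbon). Going by the values given here, no measured step covers this change. The nearest is an at least 9.5-fold lower number from compound 1 to compound 2 (0.98 log units; beyond the scatter), where 2-chlorophenyl replaces 3-methylphenyl on an amine nitrogen. That step shows that a substituent change can move the number in this series, but it is a different change at a different place, so it gives neither size nor direction here.

The starting point is therefore the value of compound 3, 17000 nM, and the upper side is bounded by the limit of > 20000 nM in this assay, at which 1 of the 3 values shown sits. The expected step is a 1.2-fold lower number from compound 3 to compound 4 (0.08 log units; within the scatter), not beyond the scatter. The estimate for compound 4 is 14000 nM, with an expected range of 5000 nM to 20000 nM.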

Compound 4, half-maximal inhibitory concentration: > 20000 nM
Compound 4 ended at the assay's limit; the forecaster's own chance of this, stated with the estimate: 35%; middle value at least 1.4-fold (0.15 log units) away from the limit.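

In this assay, going by these compounds, methyl in place of butoxy on this aromatic carbon gives an at least 1.1-fold higher number from compound 3 to compound 4 (0.07 log units; that floor lies within the scatter), so the change brings no lower number, while its true size stays unknown and butoxy cannot be ranked above methyl here. Going by these compounds alone, with (4-methylphenyl)carbonyl in place of 2-chlorophenyl on the amine nitrogen, the series shows an at least 9.5-fold higher number from compound 2 to compound 4 (0.98 log units; beyond the scatter), a clear separation that the earlier compounds did not give for this pair of groups. The value of compound 4 is a limit of the assay, and any reading of this position is capped by it: the limit of > 20000 nM in this assay, at which 2 of the 4 values shown sit.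

The step between compound 1 and compound 4 cannot be read, as both values are limits. On these data alone, whether an amine, a carboxylic acid or a chain longer than butoxy at this place would bring the number clear of that limit stays open.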